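Series notes: ethoxycarbonyl in place of ethynyl

A few compounds are considered here, and "the series" means these few. Any claim that something is new, unique, unknown or untested is made for them only; others in the source may bear on it.

In a functional assay on MDA-MB-231 cells (Homo sapiens) for antiproliferative activity, read by MTT assay, with a stated time of 72 h (a lower number here means a stronger inhibitor, a higher number a weaker inhibitor), compound 1 `O=C(CCc1cccc2c1B(O)OC2)NC1CCCCC1`, with a cyclohexyl on the amide-type nitrogen, gives only a limit, > 100000 nM.
Compound 2 `O=C(CCc1cccc2c1B(O)OC2)Nc1ccc(F)cc1` gives 440 nM.
The 4-fluorophenyl in place of cyclohexyl thus brings an at least 220-fold lower number from compound 1 to compound 2 (2.35 log units; beyond the scatter).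
Compound 3 `C#Cc1ccc(NC(=O)CCc2cccc3c2B(O)OC3)cc1` gives 6600 nM, the higher of the two actual numbers in the series.
Ethynyl in place of fluoro on the aromatic carbon brings a 15-fold higher number from compound 2 to compound 3 (1.18 log units; beyond the scatter).

Compound 4 `CCOC(=O)c1ccc(NC(=O)CCc2cccc3c2B(O)OC3)cc1` carries ethoxycarbonyl in place of ethynyl on the same aromatic carbon, para to a large group: ethoxycarbonyl in place of ethynyl on an aromatic carbon.
Among the measured compounds shown here, the closest precedent is a 15-fold higher number from compound 2 to compound 3 (1.18 log units; beyond the scatter), a large step made at this same place, so a change here can exceed the scatter in this assay.
The aromatic ring on the amide-type nitrogen stays, so a return towards the limit, reversing an at least 220-fold lower number from compound 1 to compound 2 (2.35 log units; beyond the scatter), is not expected.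
With only two substituents compared at this place, direction is uncertain, and a moderate move is expected.
The expected change is a 2.2-fold lower number from compound 3 to compound 4 (0.34 log units; beyond the scatter).
For compound 4 the estimated value is 3000 nM, with an expected range of 500 nM to 20000 nM.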

Compound 4, half-maximal inhibitory concentration: > 100000 nM
Compound 4 was reported as a limit; the forecaster's own chance of this, stated with the estimate: 5%; middle value at least 33-fold (1.52 log units) from the limit.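

Compound 4 gives only a limit, and the series now has two compounds there: the limit of > 100000 nM in this assay, at which 2 of the 4 values shown sit.

At the aromatic carbon para to a large group, ethoxycarbonyl gives a much larger change than ethynyl did, with an at least 15-fold higher number from compound 3 to compound 4 (1.18 log units; beyond the scatter) and an at least 220-fold higher number from compound 2 to compound 4 (2.35 log units; beyond the scatter). The aromatic ring on the amide-type nitrogen therefore does not secure a measurable number in this assay, which compound 1 and compound 2 alone left possible: a single change at this place is enough to reach the limit.

Going by these compounds, how a carboxylic acid, an amine or a methyl ester would read at this place stays open, and with it whether the change goes with the carbonyl or with the whole ethoxycarbonyl. The three substituents compared here give no order that can be extended to other groups.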